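Chloro in place of methyl on the fused ring

The source may report more compounds than this note shows. Statements on the series, on what has been measured and on what is new or still open speak of the compounds shown alone.

Going by the values given here, compound 3 `COc1ccccc1N1CCN(C(=O)CCc2c(-c3ccc(Cl)cc3)[nH]c3ccc(C)cc23)CC1` is the strongest of the three compounds measured so far: in an assay on CHO cells for displacement of a labelled ligand from Substance-P receptor (Homo sapiens) (a lower number here means a stronger inhibitor, a higher number a weaker inhibitor), compound 3 gives 0.6 nM. Compound 1 `COc1ccccc1N1CCN(C(=O)CCc2c(-c3ccccc3)[nH]c3ccc(C)cc23)CC1` gives 6.1 nM in this assay, and compound 2 `COc1ccc(-c2[nH]c3ccc(C)cc3c2CCC(=O)N2CCN(c3ccccc3OC)CC2)cc1` gives 1.5 nM. Both steps toward compound 3 were clear gains: a 10-fold lower number from compound 1 to compound 3 (1.01 log units; beyond the scatter) and a 2.5-fold lower number from compound 2 to compound 3 (0.40 log units; beyond the scatter), and in each a chloro entered the phenyl ring that hangs from the shared core.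

Compound 4 `COc1ccccc1N1CCN(C(=O)CCc2c(-c3ccc(Cl)cc3)[nH]c3ccc(Cl)cc23)CC1` differs from compound 3 in one place: chloro in place of methyl on an aromatic carbon. Among the compounds with values here, no measured step touches this ring, so the earlier gains give only indirect guidance; they show that a chloro has so far been tolerated and helpful, but on a different ring. The change here swaps one small group for another of the same size, and the expectation is therefore a step no larger than the scatter, if anything a slight lowering, a 1.2-fold lower number from compound 3 to compound 4 (0.08 log units; within the scatter). Compound 4 is expected to give about 0.5 nM in this assay, within a range from 0.15 nM to 1.6 nM.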

Compound 4, half-maximal inhibitory concentration: 0.89 nM
Compound 4: middle estimate off by 1.8-fold (0.25 log units), on the low side; the range from low to high includes it.
By their numbers in this assay, from the lowest: compounds 3, 4 and 2 (each within the scatter of the next, the first and the last beyond it); then compound 1.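

In this assay, the first change shown at this position, chloro in place of methyl on the fused ring, gives a 1.5-fold higher number from compound 3 to compound 4 (0.17 log units; within the scatter), so the two groups cannot be told apart here. A chloro therefore does not bring a gain wherever it enters: on the phenyl ring that hangs from the shared core it gave a 10-fold lower number from compound 1 to compound 3 (1.01 log units; beyond the scatter), whereas on this ring the step stays within the scatter. The data offer no measurement that explains why the two groups read alike here.

From the compounds shown here alone, only methyl and chloro are seen at this position, so the effect of a methoxy, an amine or a carboxylic acid there remains open. Also open, going by these compounds, is whether chloro on this ring would read the same alongside the unsubstituted phenyl ring of compound 1 or the methoxy-bearing ring of compound 2.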